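The source may report more compounds than this note shows. Statements on the series, on what has been measured and on what is new or still open speak of the compounds shown alone.

Measured in a toxicity assay on MRC5 cells (Homo sapiens) for inhibition, read by MTT assay, with a stated time of 72 h; on this read-out lower numbers stand for stronger inhibition and higher numbers for weaker inhibition:

compound 1, `CCCCCC(=O)OCCc1ccc(O)cc1`: 166000 nM
compound 3, `O=S(=O)(O)Oc1ccc(CCO)cc1`: 106000 nM
compound 2, `CCCCCCCCCCC(=O)OCCc1ccc(OCc2ccc(OC)cc2)c(OCc2ccc(OC)cc2)c1`: > 50000 nM

The value for compound 2 is a limit of this assay, not a number; the limit of > 50000 nM in this assay, at which 1 of the 3 values shown sits, describes it. Going by the values given here, two numbers remain, and compound 1 stands as the higher of them, with compound 3 as its only neighbour; the gap between the two is within the scatter of repeated measurements, so no order between compound 1 and compound 3 can be read from them.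

Among the compounds with values here, no pair of measured compounds differs in a single place, so no measured step is available to anchor the change under study.

Compound 4, `CCCCCCCC(=O)OCCc1ccc(O)cc1`, is not yet measured in this assay. From compound 1 it differs by ethyl in place of hydrogen on a saturated chain carbon, five bonds along the chain from a carbonyl carbon. The difference is a lengthening of the saturated chain and nothing else; no ring, donor, acceptor or charge is touched. Within the data shown here, no measured step of this kind exists. The expected step is estimated as a 1.7-fold lower number from compound 1 to compound 4 (0.22 log units; within the scatter), small and not clearly beyond the scatter. Compound 4 is therefore estimated at 100000 nM, with a range from 40000 nM to 250000 nM.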

Compound 4, half-maximal inhibitory concentration: 133000 nM
The estimate for compound 4 lay 1.3-fold (0.12 log units) below the measured number; the range from low to high includes it.
By their numbers in this assay, from the lowest: compounds 3, 4 and 1 (each within the scatter of the next).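

In this assay, going by these compounds alone, the only step measured at this position is a 1.2-fold lower number from compound 1 to compound 4 (0.10 log units; within the scatter), for ethyl in place of hydrogen on a saturated chain carbon, five bonds along the chain from a carbonyl carbon. This gives the series its first pair of compounds differing in one place, and the lengthening of the saturated chain produces no difference that can be read from the scatter of the assay. No measurement shown gives a cause for the size of this step, and the only limit in the series, on a compound that differs in more than one place, does not bear on it.

A single step within the scatter supports no trend with chain length, so nothing can yet be said about how the read-out follows the saturated chain on the shared core. Going by these compounds, whether an amine or a carboxylic acid at the end of the chain, in place of the ethyl of compound 4, would move the number beyond the scatter from compound 1 remains open.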